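Thiourea-to-urea switch at the ring nitrogen of the fused core

The source may report more compounds than this note shows. Statements on the series, on what has been measured and on what is new or still open speak of the compounds shown alone.

Going by the values given here, compound 3 `COc1ccc(NC(=S)N2CCc3c(sc(NC(=O)c4ccccc4Cl)c3C(N)=O)C2)cc1` gives 15700 nM in a functional assay on HL-60 cells (Homo sapiens) for antiproliferative activity, with a stated time of 24 h (a higher number here means a weaker inhibitor, a lower number a stronger inhibitor), the highest of the three numbers so far. Compound 2 `CSc1ccccc1NC(=S)N1CCc2c(sc(NC(=O)c3ccccc3Cl)c2C(N)=O)C1` gives 14600 nM, and a 1.1-fold higher number from compound 2 to compound 3 (0.03 log units; within the scatter). Among the compounds with values here, compound 1 `NC(=O)c1c(NC(=O)c2ccccc2Cl)sc2c1CCN(C(=S)Nc1ccccc1I)C2` gives 4430 nM, and a 3.5-fold higher number from compound 1 to compound 3 (0.55 log units; beyond the scatter), so compound 1 is the only member that separates from compound 3 beyond the scatter.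

Compound 4 `NC(=O)c1c(NC(=O)c2ccccc2Cl)sc2c1CCN(C(=O)Nc1c(Cl)cccc1Cl)C2` differs from compound 3 by a group of 11 heavy atoms (7 carbon, 1 nitrogen, 1 oxygen, 2 chlorine; one six-membered aromatic ring of carbon only) in place of a group of 11 heavy atoms (8 carbon, 1 nitrogen, 1 oxygen, 1 sulfur; one six-membered aromatic ring of carbon only), on an amine nitrogen in a ring. The measured steps that bear on this change all alter the aryl group on the amide-type nitrogen while keeping the thiourea: a 3.3-fold higher number from compound 1 to compound 2 (0.52 log units; beyond the scatter) and a 3.5-fold higher number from compound 1 to compound 3 (0.55 log units; beyond the scatter), both modest, whereas the step from compound 2 to compound 3 stays within the scatter. Within the data shown here, no measured pair exchanges the thiourea for a urea, so that part of the change is unanchored. Given that the 2-iodophenyl analogue compound 1 sits lowest at 4430 nM, a modest lower number is expected for compound 4, with a 2.2-fold lower number from compound 3 to compound 4 (0.35 log units; beyond the scatter), and compound 4 is estimated at 7000 nM within 2500 nM to 20000 nM.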

Compound 4, half-maximal inhibitory concentration: 17700 nM
For compound 4 the middle estimate is 2.5-fold (0.40 log units) below the measured one, within the range that was stated.
By their numbers in this assay, from the lowest: compound 1; then compounds 2, 3 and 4 (each within the scatter of the next).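

In this assay, the change to (2,6-dichlorophenyl)carbamoyl on the amine nitrogen in a ring gives a 1.1-fold higher number from compound 3 to compound 4 (0.05 log units; within the scatter) and a 1.2-fold higher number from compound 2 to compound 4 (0.08 log units; within the scatter), so the urea compound 4 cannot be told apart from the thioureas compound 2 and compound 3. The other comparison, a 4.0-fold higher number from compound 1 to compound 4 (0.60 log units; beyond the scatter), shows that a chlorine-bearing aryl urea does not reproduce the lower number of the 2-iodophenyl thiourea, leaving compound 1 alone in separating from the others beyond the scatter. Nothing on hand accounts for these steps.

The carbonyl-for-thiocarbonyl exchange and the aryl change occur together here, so a urea carrying 2-iodophenyl would be needed to read either one alone. Also open, as far as these compounds go, is how this position responds to a non-aromatic substituent, such as a longer alkyl chain, or to an aryl group carrying a carboxylic acid or an amine.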